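Swapping Benzyloxy for Methyl on Compound 1

The compounds below may be only part of what the source reports. "The series", "measured", "known", "first", "only" and "open" are said of these compounds alone.

For the measured compounds named here, in a functional assay on HepG2 cells (Homo sapiens) for cytotoxicity, read by spectrophotometry, with a stated time of 72 h (a higher number here means a weaker inhibitor, a lower number a stronger inhibitor), compound 1 (`COc1ccc(-c2cccc(=O)n2-c2cc(OC)c(OC)c(OC)c2)cc1OCc1ccccc1`) gives 269 nM and compound 2 (`COc1cc(-n2c(-c3cccc(F)c3)cccc2=O)cc(OC)c1OC`) gives 159 nM as the only other measured value. The two lie within the scatter of each other, so compound 1 stands level with compound 2. Compound 3 (`COc1ccc(-c2cccc(=O)n2-c2cc(OC)c(OC)c(OC)c2)cc1C`) has not yet been measured. It matches compound 1 except for methyl in place of benzyloxy on an aromatic carbon ortho to a methoxy group. Going by the values given here, no measured pair isolates this change. Compound 2 carries no benzyloxy group and gives 159 nM all the same, so losing that group is not expected to cost much. In this assay the estimated step of a 1.6-fold lower number from compound 1 to compound 3 (0.20 log units; within the scatter) is expected to be small, toward a lower number and within the scatter. Compound 3 is estimated at 170 nM (50 nM to 550 nM) as its expected value and range.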

Compound 3, half-maximal inhibitory concentration: 129 nM
The estimate for compound 3 lay 1.3-fold (0.12 log units) above the measured number; the range from low to high includes it.
By their numbers in this assay, from the lowest: compounds 3, 2 and 1 (each within the scatter of the next, the first and the last beyond it).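

In this assay, for the compounds shown here, this pair gives the first direct reading of the place ortho to a methoxy group: methyl in place of benzyloxy on an aromatic carbon gives a 2.1-fold lower number from compound 1 to compound 3 (0.32 log units; beyond the scatter), a modest step. The benzyloxy group, with its six-membered aromatic ring of carbon only, is therefore not needed here, and the much smaller methyl gives the stronger inhibitor of this pair. Putting 4-methoxy-3-methylphenyl in place of 3-fluorophenyl on an aromatic carbon gives a 1.2-fold lower number from compound 2 to compound 3 (0.09 log units; within the scatter), so these two substituents cannot be told apart in this assay.

No accompanying measurement accounts for the step from benzyloxy to methyl. On these data alone, whether an ethoxy group, an amine or a carboxylic acid at this place would keep the number at this level remains open.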